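The source may report more compounds than this note shows. Statements on the series, on what has been measured and on what is new or still open speak of the compounds shown alone.

Measured so far in an ADME assay on cells (Macrophage, Homo sapiens) for cytotoxicity, read by MTT assay, with a stated time of 24 h; on this read-out lower numbers stand for higher toxicity in this test and higher numbers for lower toxicity in this test:
- compound 1 `CC(O)Cn1c([N+](=O)[O-])cnc1/C=C/c1ccc(Br)cc1` gives 550 nM
- compound 2 `CC(O)Cn1c([N+](=O)[O-])cnc1/C=C/c1ccc(F)cc1` gives 420 nM
- compound 3 `CC(O)Cn1c([N+](=O)[O-])cnc1/C=C/c1ccccc1Cl` gives 480 nM

Compound 1 holds the highest of the three numbers in this assay, yet its nearest neighbour compound 3 sits only a 1.1-fold lower number from compound 1 to compound 3 (0.06 log units; within the scatter) away, and the furthest, compound 2, only a 1.3-fold lower number from compound 1 to compound 2 (0.12 log units; within the scatter). All three values therefore lie within the scatter of one another, and no ordering among them can be read from this assay.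

Compound 4 `Cc1ccc(/C=C/c2ncc([N+](=O)[O-])n2CC(C)O)cc1` has not yet been measured. Relative to compound 1 the change is:
methyl in place of bromo on an aromatic carbon

For the measured compounds named here, the step that bears most directly on this is the one from compound 1 to compound 2, where a different halogen took the place of bromo on the same aromatic carbon: a 1.3-fold lower number from compound 1 to compound 2 (0.12 log units; within the scatter). The move to a 2-chlorophenyl in compound 3 was likewise small, a 1.1-fold higher number from compound 2 to compound 3 (0.06 log units; within the scatter) from compound 2. Exchanges on this phenyl ring have so far not moved this assay beyond the scatter, so a methyl in place of bromo is expected to behave the same way, with no step beyond the scatter in either direction.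

Compound 4 is therefore estimated at 500 nM in this assay, with a range from 250 nM to 1100 nM, which corresponds to an expected step of a 1.1-fold lower number from compound 1 to compound 4 (0.04 log units; within the scatter).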

Compound 4, half-maximal cytotoxic concentration: 860 nM
The estimate for compound 4 lay 1.7-fold (0.24 log units) below the measured number; low and high end bracket the measured number.
By their numbers in this assay, from the lowest: compounds 2, 3, 1 and 4 (each within the scatter of the next, the first and the last beyond it).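

In this assay, the exchange of bromo for methyl on this aromatic carbon gives a 1.6-fold higher number from compound 1 to compound 4 (0.19 log units; within the scatter), and the change from 2-chlorophenyl to 4-methylphenyl gives a 1.8-fold higher number from compound 3 to compound 4 (0.25 log units; within the scatter), so neither step leaves the scatter. The new finding is a 2.0-fold higher number from compound 2 to compound 4 (0.31 log units; beyond the scatter), a modest step and the only one among these phenyl exchanges to pass the scatter, which means that methyl separates from fluoro on this carbon but not from bromo, and compound 4 cannot be set apart from compound 1 or compound 3. Nothing available gives a reason for this step.

Still open, going by these compounds, is whether an amine, a carboxylic acid or a longer chain such as propyl on this aromatic carbon would stay close to these values or move clearly beyond the scatter from compound 4. On these data alone, all four compounds share the rest of the core, so how this read-out responds to changes outside the phenyl ring also remains open.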